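The compounds below may be only part of what the source reports. "The series", "measured", "known", "first", "only" and "open" are said of these compounds alone.

The measured compounds and their results in an ADME assay on Vero cells (Chlorocebus sabaeus) for cytotoxicity, read by MTT assay, with a stated time of 72 h (on this read-out lower numbers stand for stronger inhibition and higher numbers for weaker inhibition), are these:
compound 1 `COc1cccc(-c2csc(NC(=O)c3ccc([N+](=O)[O-])o3)n2)c1` gives 58700 nM;
compound 2 `O=C(Nc1nc(-c2cccc(OC3CCCC3)c2)cs1)c1ccc([N+](=O)[O-])o1` gives 81100 nM;
compound 3 `O=C(Nc1nc(-c2cccc(NC(=O)C3CCCC3)c2)cs1)c1ccc([N+](=O)[O-])o1` gives "not determined" (no result reported), so no number exists for it.

Of the two numbers in hand, compound 1 has the smaller one. Going by the values given here, its only neighbour with a number is compound 2, and the step of a 1.4-fold higher number from compound 1 to compound 2 (0.14 log units; within the scatter) is within the scatter, so the two compounds are not separated by this assay. Among the compounds with values here, that step, cyclopentyl in place of methyl on an oxygen on an aromatic ring, is the only measured step in the set.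

Compound 4 `O=C(Nc1nc(-c2cccc(NC(=O)C3CCCCC3)c2)cs1)c1ccc([N+](=O)[O-])o1` differs from compound 1 as follows: (cyclohexylcarbonyl)amino in place of methoxy on an aromatic carbon. Compound 3, whose structure stands above, is the closest relative of compound 4, but no number exists for it, so nothing about this kind of change has been measured. Within the data shown here, the one step that bears at all on compound 4, a 1.4-fold higher number from compound 1 to compound 2 (0.14 log units; within the scatter), enlarges the substituent at the same position and stays within the scatter.

On that basis compound 4 is expected to show a step of a 1.2-fold higher number from compound 1 to compound 4 (0.08 log units; within the scatter), which is no change beyond the scatter. The estimate for compound 4 in this assay is 70000 nM, with a range from 25000 nM to 200000 nM.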

Compound 4, half-maximal inhibitory concentration: 21900 nM
Beside the measured number, compound 4's estimate is 3.2-fold (0.50 log units) above it; measured number below the stated range.
By their numbers in this assay, from the lowest: compound 4; then compounds 1 and 2 (each within the scatter of the next).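

In this assay, (cyclohexylcarbonyl)amino in place of methoxy on this aromatic carbon gives a 2.7-fold lower number from compound 1 to compound 4 (0.43 log units; beyond the scatter) and, set against the cyclopentyloxy group at the same place, gives a 3.7-fold lower number from compound 2 to compound 4 (0.57 log units; beyond the scatter) as a second modest step beyond the scatter. Going by these compounds alone, the earlier compounds had only varied the group on the oxygen, and that step stayed within the scatter, so this result is the first to show that the number at this position can move beyond the scatter, here with an amide-linked group that carries one hydrogen-bond donor and a six-membered non-aromatic ring of carbon only. No measurement is available that would explain this shift.

Because compound 4 differs from the two ethers in both its link and its ring, the compounds shown do not separate the contribution of the amide link from that of the cyclohexyl ring. They also leave open how a small acetylamino group, a free amine or a carboxylic acid on this aromatic carbon would compare with (cyclohexylcarbonyl)amino.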